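Swapping an Amide for a Methyl Ester: Solubility Outlook

The compounds below may be only part of what the source reports. "The series", "measured", "known", "first", "only" and "open" are said of these compounds alone.

Compound 2 `Cc1cc(/C=C/C#N)cc(C)c1Oc1cc(Nc2ccc(C#N)cc2)c(N)cc1C(=O)NCCCO` sits lowest of the three numbers measured in a physicochemical assay for solubility, read by HPLC, in phosphate buffer, with a stated time of 4 h, at pH 7.4 (a higher number here means a more soluble compound, a lower number a less soluble compound), where compound 2 gives 1.01 ug/mL. Compound 1 `Cc1cc(/C=C/C#N)cc(C)c1Oc1cc(Nc2ccc(C#N)cc2)c(N)cc1C(=O)NN` gives 2.4 ug/mL and compound 3 `Cc1cc(/C=C/C#N)cc(C)c1Oc1cc(Nc2ccc(C#N)cc2)c(N)cc1C(=O)N1CC1` gives 1.2 ug/mL. These three share one core and differ only in what the carbonyl carbon carries; compound 4 `COC(=O)c1cc(N)c(Nc2ccc(C#N)cc2)cc1Oc1c(C)cc(/C=C/C#N)cc1C` changes that place once more: methoxy in place of (3-hydroxypropyl)amino on a carbonyl carbon. Within the data shown here, no measured step makes exactly this change. The nearest ones are a 2.4-fold lower number from compound 1 to compound 2 (0.38 log units; beyond the scatter) and a 1.2-fold higher number from compound 2 to compound 3 (0.07 log units; within the scatter), both modest, so changes at this carbonyl carbon have moved the number only a little so far. A small step is therefore expected in this assay, namely a 1.0-fold lower number from compound 2 to compound 4 (0.00 log units; within the scatter). Compound 4 is estimated at 1 ug/mL, with a range from 0.3 ug/mL to 3 ug/mL.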

Compound 4, solubility: 1.21 ug/mL
The estimate for compound 4 lay 1.2-fold (0.08 log units) below the measured number, and the stated range covers the measured number.
By their numbers in this assay, from the lowest: compounds 2, 3, 4 and 1 (each within the scatter of the next, the first and the last beyond it).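

Trading (3-hydroxypropyl)amino for methoxy on this carbonyl carbon removes both hydrogen-bond donors of the leaving group, yet this assay shows a 1.2-fold higher number from compound 2 to compound 4 (0.08 log units; within the scatter). The other comparisons give a 1.0-fold higher number from compound 3 to compound 4 (0.00 log units; within the scatter) and a 2.0-fold lower number from compound 1 to compound 4 (0.30 log units; within the scatter), so methoxy adds a fourth group to a narrow set of numbers, in which only compound 1 and compound 2 lie beyond the scatter of each other. Nothing available explains these numbers. Still open, as far as these compounds go, is whether a group carrying an amine on a longer chain, or a carboxylic acid at this place, would give a larger step.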